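The Same Methoxy Step Tried on an Oxime Analogue

A few compounds are considered here, and "the series" means these few. Any claim that something is new, unique, unknown or untested is made for them only; others in the source may bear on it.

Measured so far in a functional assay on HT-29 cells (Homo sapiens) for inhibition, read by MTT assay, with a stated time of 48 h; on this read-out higher numbers stand for weaker inhibition and lower numbers for stronger inhibition:
- compound 1 `Cn1c(=O)c2[nH]c(SCC(=O)c3ccccc3)nc2n(C)c1=O` gives 5900 nM
- compound 2 `COc1ccc(C(=O)CSc2nc3c([nH]2)c(=O)n(C)c(=O)n3C)cc1` gives 8100 nM
- compound 3 `Cn1c(=O)[nH]c2nc(SC/C(=N/O)c3ccccc3)[nH]c2c1=O` gives 2100 nM

Compound 2 differs from compound 1 by methoxy in place of hydrogen on an aromatic carbon, and this change brought a 1.4-fold higher number from compound 1 to compound 2 (0.14 log units; within the scatter). Compound 3 has the lowest of the three numbers; how its core differs from the core of compound 1 is not broken down here. Compound 4 `COc1ccc(/C(CSc2nc3[nH]c(=O)n(C)c(=O)c3[nH]2)=N\O)cc1` differs from compound 3 by methoxy in place of hydrogen on an aromatic carbon, the same change as from compound 1 to compound 2, at the same place. Because a 1.4-fold higher number from compound 1 to compound 2 (0.14 log units; within the scatter) stayed within the scatter, the step of a 1.4-fold higher number from compound 3 to compound 4 (0.14 log units; within the scatter) is expected to be of similar size. Compound 4 is therefore estimated at 2900 nM in this assay, most likely between 1200 nM and 7000 nM.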

Compound 4, half-maximal inhibitory concentration: 1700 nM
For compound 4 the middle estimate is 1.7-fold (0.23 log units) above the measured one, within the range that was stated.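

In this assay, methoxy in place of hydrogen on the aromatic carbon gave a 1.2-fold lower number from compound 3 to compound 4 (0.09 log units; within the scatter), a step as small on the core of compound 3 as on the core of compound 1. Set side by side, the two steps agree: the same change on two cores in this assay, a 1.4-fold higher number (0.14 log units; within the scatter) from compound 1 to compound 2 and a 1.2-fold lower number (0.09 log units; within the scatter) from compound 3 to compound 4, 1.7-fold (0.23 log units) apart, within the scatter of two such steps. The change therefore carried from one core to the other without a step beyond the scatter, but neither pair shows that methoxy really moves the number in either direction, and two pairs set no rule for other cores.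

The compounds shown carry only hydrogen or methoxy at this place on the aromatic ring. As far as these compounds go, whether an amine, a carboxylic acid or a longer chain there would give a step beyond the scatter on either core remains open.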